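This account rests on a few compounds, and the source may have more. Where it says the series, first, only, none or still open, it means among the compounds named here.

Compound 1 `COc1ccc(/C=C/C(=O)c2cc(NC(C)=O)ccc2O)cc1` and compound 2 `CC(=O)Nc1ccc(O)c(C(=O)/C=C/c2ccc(F)cc2)c1` share one core, while compound 3 `COc1ccccc1-c1cc(=O)c2cc(NC(C)=O)ccc2o1` and compound 4 `CC(=O)Nc1ccc2oc(-c3ccccc3F)cc(=O)c2c1` share another; the difference between the two cores is not broken down here. In an ADME assay on MT4 cells (Homo sapiens) for cytotoxicity, read by MTT assay, with a stated time of 4 days (a lower number here means that less compound is tolerated, a higher number that more compound is tolerated), compound 1 gives 38700 nM, and compound 2 gives 41100 nM. The step of a 1.1-fold higher number from compound 1 to compound 2 (0.03 log units; within the scatter) belongs to the change (fluoro in place of methoxy on an aromatic carbon). Compound 3 gives 226000 nM in this assay, a higher number than either compound 1 or compound 2 by more than the usual scatter. Compound 4 differs from compound 3 by fluoro in place of methoxy on an aromatic carbon. For the measured compounds named here, this is the same kind of change as the one from compound 1 to compound 2, not the same one: in compound 2 the fluoro sits para to a large group, whereas in compound 4 it sits ortho to a large group. Because the step of a 1.1-fold higher number from compound 1 to compound 2 (0.03 log units; within the scatter) stayed within the scatter, the step from compound 3 to compound 4 is expected to be small as well, about a 1.1-fold lower number from compound 3 to compound 4 (0.05 log units; within the scatter). Compound 4 is therefore estimated to give about 200000 nM in this assay, between 80000 nM and 500000 nM.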

Compound 4, half-maximal cytotoxic concentration: 205000 nM
The estimate for compound 4 lay 1.0-fold (0.01 log units) below the measured number; measured number inside the range.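

In this assay, putting fluoro in place of methoxy on the core of compound 3 gives a 1.1-fold lower number from compound 3 to compound 4 (0.04 log units; within the scatter), and the two steps for this change agree: the same change on two cores in this assay, a 1.1-fold higher number (0.03 log units; within the scatter) from compound 1 to compound 2 and a 1.1-fold lower number (0.04 log units; within the scatter) from compound 3 to compound 4, 1.2-fold (0.07 log units) apart, within the scatter of two such steps. So in these four compounds, the swap leaves the tolerated concentration essentially unmoved on both cores, and what was seen on the first core held on the second. For the compounds shown here, this does not show that the swap is without effect on every core, as it rests on only two pairs, and it says nothing about whether a change with a large effect would carry across these cores equally well.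

On these data alone, only methoxy and fluoro appear at this spot, so it remains open whether an amine, a carboxylic acid or a longer chain such as butoxy would also leave the number unmoved on either core. As far as these compounds go, it is also open whether the two cores would still agree with fluoro placed elsewhere on this ring.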